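The source may hold more compounds than are shown below. What is called first, only, known or untested is meant among the compounds shown, and "the series" means these compounds.

In a functional assay on HSC-2 cells (Homo sapiens) for cytotoxicity, with a stated time of 24 h (on this read-out higher numbers stand for lower toxicity in this test and lower numbers for higher toxicity in this test), compound 1 `O=C1/C(=C/c2ccc(Cl)cc2)CCC/C1=C\c1ccccc1[N+](=O)[O-]` gives 3700 nM and compound 3 `COc1ccc(/C=C2\CCC/C(=C\c3ccccc3[N+](=O)[O-])C2=O)cc1` gives 11000 nM. Compound 2 `CN(C)c1ccc(/C=C2\CCC/C(=C\c3ccccc3[N+](=O)[O-])C2=O)cc1` gives > 400000 nM, which is a limit and not a number: the limit of > 400000 nM in this assay, at which 1 of the 3 values shown sits.

Compound 4 `CN(C)c1ccc(/C=C2\CCC/C(=C\c3cccc([N+](=O)[O-])c3)C2=O)cc1` carries one change from compound 2, (3-nitrophenyl in place of 2-nitrophenyl on a double-bonded chain carbon bound to a double-bonded ring carbon).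

Within the data shown here, no measured step touches the nitrophenyl group. The measured steps all lie at the other aromatic ring: an at least 100-fold higher number from compound 1 to compound 2 (2.03 log units; beyond the scatter) and an at least 36-fold lower number from compound 2 to compound 3 (1.56 log units; beyond the scatter) are large, while a 3.0-fold higher number from compound 1 to compound 3 (0.47 log units; beyond the scatter) is modest. Compound 4 keeps the dimethylamino group, and the large at least 100-fold higher number from compound 1 to compound 2 (2.03 log units; beyond the scatter) came with that group, so a high number is expected in this assay.

At most a modest move toward lower numbers is expected, estimated as an at least 2.0-fold lower number from compound 2 to compound 4 (0.30 log units; that floor lies within the scatter). Compound 4 is estimated at 200000 nM, within an expected range of 40000 nM to 400000 nM.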

Compound 4, half-maximal cytotoxic concentration: 32000 nM
Beside the measured number, compound 4's estimate is 6.3-fold (0.80 log units) above it; measured number below the stated range.
By their numbers in this assay, from the lowest: compound 1; then compound 3; then compound 4. At a limit, above all of these: compound 2.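

On the double-bonded chain carbon bound to a double-bonded ring carbon, 3-nitrophenyl in place of 2-nitrophenyl moves the read-out in this assay, giving an at least 12-fold lower number from compound 2 to compound 4 (1.09 log units; beyond the scatter). The nitrophenyl group therefore also matters in this series, and with the dimethylamino group kept, a measured number is reached. The size of this step is only a floor, as compound 2 stands at a limit and not at a number: the limit of > 400000 nM in this assay, at which 1 of the 4 values shown sits.

On these data alone, whether the same change acts alike with chloro or methoxy on the other aromatic ring stays open. So does the effect of an amine or a carboxylic acid in place of the nitro group.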